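Phenoxy substituent change, compound 3 to compound 4

This account rests on a few compounds, and the source may have more. Where it says the series, first, only, none or still open, it means among the compounds named here.

Within the data shown here, compound 3 `CCc1ccc(OCc2cn(-c3cc(=O)oc4ccc(Br)cc34)nn2)cc1` gives 10800 nM in a functional assay on SW480 cells (Homo sapiens) for antiproliferative activity, read by MTT assay, with a stated time of 48 h (on this read-out lower numbers stand for stronger inhibition and higher numbers for weaker inhibition), and holds the second highest of the three numbers so far. Compound 2 `O=c1cc(-n2cc(COc3ccccc3O)nn2)c2cc(Br)ccc2o1` sits within the scatter of it at 19100 nM (a 1.8-fold lower number from compound 2 to compound 3 (0.25 log units; within the scatter)), whereas compound 1 `O=c1cc(-n2cc(COc3ccccc3)nn2)c2cc(Br)ccc2o1` at 4990 nM lies beyond it (a 2.2-fold higher number from compound 1 to compound 3 (0.34 log units; beyond the scatter)).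

Compound 4 `O=c1cc(-n2cc(COc3ccc(F)cc3)nn2)c2cc(Br)ccc2o1` differs from compound 3 by fluoro in place of ethyl on an aromatic carbon. Among the measured compounds shown here, no measured step makes this exact swap. The step that bears on it is the entry of ethyl at this place, a 2.2-fold higher number from compound 1 to compound 3 (0.34 log units; beyond the scatter), which was modest; a 3.8-fold higher number from compound 1 to compound 2 (0.58 log units; beyond the scatter) concerns another position on the ring. Replacing ethyl with fluoro is expected to give back part of that step, and a 1.7-fold lower number from compound 3 to compound 4 (0.22 log units; within the scatter) is estimated as a modest move to a lower number. Compound 4 is estimated at 6500 nM, within 3000 nM to 15000 nM.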

Compound 4, half-maximal inhibitory concentration: 1770 nM
Beside the measured number, compound 4's estimate is 3.7-fold (0.56 log units) above it; measured number below the stated range.
By their numbers in this assay, from the lowest: compound 4; then compound 1; then compounds 3 and 2 (each within the scatter of the next).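

In this assay, the aromatic carbon para to a large group now moves in both directions: ethyl raised the number from compound 1 to compound 3, while fluoro gives a 2.8-fold lower number from compound 1 to compound 4 (0.45 log units; beyond the scatter). Among these compounds, the exchange of ethyl for fluoro gives a 6.1-fold lower number from compound 3 to compound 4 (0.79 log units; beyond the scatter), and 4-fluorophenyl in place of 2-hydroxyphenyl gives an 11-fold lower number from compound 2 to compound 4 (1.03 log units; beyond the scatter), the only large step in the set. No measurement at hand accounts for these shifts.

As far as these compounds go, whether chloro, methoxy, an amine or a longer chain at this place would follow fluoro or ethyl stays open. With only hydrogen, ethyl and fluoro compared there, no trend across substituents can be drawn.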